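This account rests on a few compounds, and the source may have more. Where it says the series, first, only, none or still open, it means among the compounds named here.

Within the data shown here, compound 2, with the structure `CC(C)(C)c1ccc(C(=O)Nc2cccc(NC(=O)COc3ccc4c(=O)ccoc4c3)c2)cc1`, gives the lowest of the two numbers so far in an assay on isolated protein for inhibition of Rho-associated protein kinase 1 (Homo sapiens), read by scintillation counting, radiometric assay and 33P incorporation, with a stated time of 40 min, in the presence of a further agent that is not named here (on this read-out higher numbers stand for weaker inhibition and lower numbers for stronger inhibition), namely 165 nM. Among the measured compounds shown here, the only other measured compound, compound 1 with the structure `CC(=O)Nc1cccc(NC(=O)COc2ccc3c(=O)ccoc3c2)c1`, gives 2500 nM in this assay. For the measured compounds named here, the one measured step, a 15-fold lower number from compound 1 to compound 2 (1.18 log units; beyond the scatter), came from putting 4-(tert-butyl)phenyl in place of methyl on a carbonyl carbon, and it was large.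

Compound 3, with the structure `O=C(COc1ccc2c(=O)ccoc2c1)Nc1cccc(NC(=O)c2ccc(F)cc2)c1`, has not yet been measured in this assay. It differs from compound 2 in one place: fluoro in place of tert-butyl on an aromatic carbon, on an aromatic carbon of a six-membered aromatic ring of carbon only, para to a large group. This change keeps the aryl group that the step from compound 1 to compound 2 introduced but strips away its tert-butyl, so part of that gain is expected to be lost. Compound 3 is therefore expected to give 500 nM in this assay, within a range of 150 nM to 1600 nM, a step of a 3.0-fold higher number from compound 2 to compound 3 (0.48 log units; beyond the scatter) toward a higher number.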

Compound 3, half-maximal inhibitory concentration: 129 nM
The estimate for compound 3 lay 3.9-fold (0.59 log units) above the measured number; measured number outside the range, below it.
By their numbers in this assay, from the lowest: compounds 3 and 2 (each within the scatter of the next); then compound 1.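

Replacing tert-butyl with fluoro gives a 1.3-fold lower number from compound 2 to compound 3 (0.11 log units; within the scatter) in this assay, so a group of 4 heavy atoms and a single fluorine atom at this position cannot be told apart. The step from methyl stays large with the smaller aryl group, at a 19-fold lower number from compound 1 to compound 3 (1.29 log units; beyond the scatter) for 4-fluorophenyl, so in these three compounds the large drop in the number goes with having either substituted phenyl on the carbonyl carbon, whichever of the two groups it carries. Nothing available here explains why tert-butyl and fluoro read alike.

Going by these compounds, it remains open whether a hydrogen, a methoxy group, an amine or a carboxylic acid at this position would also read alike. On these data alone, it is also open whether the phenyl ring itself matters, or whether a cyclohexyl group or a longer alkyl chain on the carbonyl carbon would do as well.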